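Triazole-linked terpenoid esters: aryl versus nucleoside groups on the triazole

A few compounds are considered here, and "the series" means these few. Any claim that something is new, unique, unknown or untested is made for them only; others in the source may bear on it.

Measured so far:
- compound 1, `C/C(=C\CC/C(C)=C/CC[C@@H]1[C@@]2(C)CCC(=O)C(C)(C)[C@H]2CC[C@@]1(C)O)CC/C=C(\C)C(=O)OCc1cn(C[C@@H]2O[C@H](n3ccc(=O)[nH]c3=O)[C@H]3OC(C)(C)O[C@H]32)nn1`: in a functional assay on A549 cells (Homo sapiens) for antiproliferative activity, read by MTT assay, with a stated time of 48 h (a lower number here means a stronger inhibitor, a higher number a weaker inhibitor), compound 1 gives 15300 nM.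
- compound 2, `C/C(=C\CC/C(C)=C/CC[C@@H]1[C@@]2(C)CCC(=O)C(C)(C)[C@H]2CC[C@@]1(C)O)CC/C=C(\C)C(=O)OCc1cn(-c2ccc(Br)cc2)nn1`: in this assay compound 2 returns only a limit, > 150000 nM.
- compound 3, `C/C(=C\CC/C(C)=C/CC[C@@H]1[C@@]2(C)CCC(=O)C(C)(C)[C@H]2CC[C@@]1(C)O)CC/C=C(\C)C(=O)OCc1cn(C[C@@H]2O[C@H](n3ccc(=O)[nH]c3=O)C[C@H]2O)nn1`: in this assay compound 3 gives 28100 nM.

The shared core is the same throughout; the series varies only the group on the triazole nitrogen. Compound 1 and compound 3, each carrying a nucleoside-derived group there, give numbers within the usual scatter of each other, so no order between them is read. For the measured compounds named here, compound 2, the one member with an aryl group on the triazole, stands at the limit of > 150000 nM in this assay, at which 1 of the 3 values shown sits; it is a limit, not a number, and the assay gave nothing more for it.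

Compound 4, `COc1ccc(-n2cc(COC(=O)/C(C)=C/CC/C(C)=C/CC/C(C)=C/CC[C@@H]3[C@@]4(C)CCC(=O)C(C)(C)[C@H]4CC[C@@]3(C)O)nn2)cc1`, is not yet measured. It keeps the aryl triazole of compound 2 and differs from it in one place only: methoxy in place of bromo on an aromatic carbon. Going by the values given here, no step between measured compounds shows how such an exchange on the aryl ring moves the read-out, so the size of the step is unknown from the data. Given that compound 2 sits at the limit of > 150000 nM in this assay, at which 1 of the 3 values shown sits, compound 4 is expected to stay in that region, with the step of a number no higher from compound 2 to compound 4 (the limit leaves the size open) expected to be none beyond the scatter. Compound 4 is estimated at 150000 nM, with a range from 50000 nM to 400000 nM, and a limit rather than a number is the likelier outcome.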

Compound 4, half-maximal inhibitory concentration: > 150000 nM
Compound 4: no number, only a limit; the forecaster's own chance of this, stated with the estimate: 70%; the middle value sits exactly at the limit.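

In this assay compound 2 gives only a limit (> 150000 nM). For the compounds shown here, compound 4 also gives only a limit (> 150000 nM), and no step from 4-bromophenyl to 4-methoxyphenyl can be read between compound 2 and compound 4. The compounds shown leave open whether any aryl group on the triazole gives a measurable number in this read-out.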